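Ethyl in Place of Cyclopropyl: Expected Tolerance of Compound 3

The compounds below may be only part of what the source reports. "The series", "measured", "known", "first", "only" and "open" are said of these compounds alone.

Measured so far:
compound 1 `CCCCc1csc(CN[C@@H]2C[C@H]3C[C@@H]([C@H]2C)C3(C)C)c1`: 12500 nM
compound 2 `C[C@H]1[C@H](NCc2cc(C3CC3)cs2)C[C@H]2C[C@@H]1C2(C)C`: 25000 nM

Both compounds were read in an ADME assay on MDCK cells (Canis lupus familiaris) for cytotoxicity, read by microscopy, with a stated time of 48 h; a higher number here means that more compound is tolerated, a lower number that less compound is tolerated. Compound 2 holds the highest of the two numbers, and its nearest neighbour is compound 1; the step of a 2.0-fold higher number from compound 1 to compound 2 (0.30 log units; within the scatter) lies within the scatter, so the two cannot be told apart on these data.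

Compound 3 `CCc1csc(CN[C@@H]2C[C@H]3C[C@@H]([C@H]2C)C3(C)C)c1` has not yet been measured in this assay. It differs from compound 2 in one place: ethyl in place of cyclopropyl on an aromatic carbon. For the measured compounds named here, the only measured step that bears on such a change is a 2.0-fold higher number from compound 1 to compound 2 (0.30 log units; within the scatter), where butyl gave way to cyclopropyl at the same aromatic carbon without moving the number beyond the scatter. On that basis compound 3 is expected to show a 1.3-fold lower number from compound 2 to compound 3 (0.10 log units; within the scatter), that is, no step beyond the scatter. The estimate for compound 3 in this assay is 20000 nM, with a range from 8000 nM to 50000 nM.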

Compound 3, minimum cytotoxic concentration: 25000 nM
Estimate against measurement, compound 3: 1.3-fold (0.10 log units) below; the range from low to high includes it.
By their numbers in this assay, from the lowest: compounds 1, 2 and 3 (each within the scatter of the next).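

The ring of cyclopropyl proves unnecessary at this aromatic carbon: in this assay the open ethyl group gives no change at the digits printed from compound 2 to compound 3 (within the scatter) and so adds a second change here that stays within the scatter. Ethyl and the longer butyl also stand close together, with a 2.0-fold higher number from compound 1 to compound 3 (0.30 log units; within the scatter) and that step too lies within the scatter. Butyl, cyclopropyl and ethyl thus cannot be told apart at this position whether the group is a chain of either length or a ring, and nothing measured here offers an explanation for this.

On these data alone, all three groups contain carbon only, so it remains open whether an amine or a carboxylic acid on this aromatic carbon would stay within the scatter. As far as these compounds go, whether plain hydrogen at this place would do so is equally open.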